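The compounds below may be only part of what the source reports. "The series", "measured", "known", "first", "only" and "open" are said of these compounds alone.

For the measured compounds named here, in a functional assay on Ishikawa cells (Homo sapiens) for inhibition, read by MTT assay, with a stated time of 48 h (on this read-out lower numbers stand for stronger inhibition and higher numbers for weaker inhibition), compound 1 `CCOC(=O)c1c(N)sc(/N=C/c2ccccc2)c1C(=O)OCC` stands at 37900 nM, and its only neighbour, compound 2 `CCOC(=O)c1c(N)sc(/N=C/c2ccco2)c1C(=O)OCC`, bearing furan-2-yl in place of phenyl on a carbon with a double bond to nitrogen, stands at 69300 nM; that step, a 1.8-fold higher number from compound 1 to compound 2 (0.26 log units; within the scatter), lies within the scatter. Compound 3 `CCOC(=O)c1c(N)sc(/N=C/c2ccc(Cl)cc2)c1C(=O)OCC` differs from compound 1 by chloro in place of hydrogen on an aromatic carbon. Going by the values given here, no measured step concerns a chloro on that ring, and the one step available, exchanging the whole ring, stayed within the scatter. In this assay the expected step is therefore a 1.2-fold lower number from compound 1 to compound 3 (0.07 log units; within the scatter), none beyond the scatter. Compound 3 is estimated at 32000 nM, between 10000 nM and 100000 nM.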

Compound 3, half-maximal inhibitory concentration: 27100 nM
Compound 3: middle estimate off by 1.2-fold (0.07 log units), on the high side; the measured number falls inside the stated range.
By their numbers in this assay, from the lowest: compounds 3, 1 and 2 (each within the scatter of the next, the first and the last beyond it).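

In this assay, chloro in place of hydrogen on the phenyl ring, para to a large group, gives a 1.4-fold lower number from compound 1 to compound 3 (0.15 log units; within the scatter) and so stays within the scatter; this position accepts the chloro without a clear change. For the compounds shown here, the only step beyond the scatter is a 2.6-fold lower number from compound 2 to compound 3 (0.41 log units; beyond the scatter) and it exchanges the whole ring, so it cannot be credited to the chloro alone. Nothing available gives a cause for either step. From the compounds shown here alone, whether an amine or a methoxy group at this position would shift the number remains open.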